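The source may hold more compounds than are shown below. What is called first, only, known or untested is meant among the compounds shown, and "the series" means these compounds.

Measured compounds, read in a functional assay on MCF7 cells (Homo sapiens) for antiproliferative activity, read by MTT assay, with a stated time of 24 h; a lower number here means a stronger inhibitor, a higher number a weaker inhibitor:

- Compound 1 `CCCCc1oc2ccccc2c1C(=O)c1ccc(OCC(N)=O)cc1`: > 50000 nM, a limit of the assay.
- Compound 2 `CCCCNC(=O)COc1ccc(C(=O)c2c(CCCC)oc3ccccc23)cc1`: > 50000 nM, likewise a limit.
- Compound 3 `CCCCc1oc2ccccc2c1C(=O)c1ccc(OCC(=O)NCc2ccccc2)cc1`: 19600 nM.

Compound 1 therefore stands only at a limit, not at a number; two of the three values sit at the limit of > 50000 nM in this assay, at which 2 of the 3 values shown sit, so most of what the set shows is that the unsubstituted and butyl amides are inactive within the range tested, while the benzyl amide of compound 3 gives a readable number.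

The next compound, compound 4 `CCCCc1oc2ccccc2c1C(=O)c1ccc(OCC(=O)N[C@H](C)c2ccccc2)cc1`, differs from compound 1 by 1-phenylethyl in place of hydrogen on an amide-type nitrogen. The step from hydrogen to benzyl is the closest guide: an at least 2.5-fold lower number from compound 1 to compound 3 (0.40 log units; beyond the scatter). The step of an at least 2.5-fold lower number from compound 2 to compound 3 (0.40 log units; beyond the scatter) points the same way, towards an aromatic ring on the chain carbon bound to the amide nitrogen, whereas a step that the two limits leave unreadable from compound 1 to compound 2 cannot be read. Compound 4 carries one more carbon on that chain than compound 3 but keeps the phenyl, so a drop of the same kind, out of the limit into a readable number, is expected; the estimate for compound 4 is 20000 nM, range 7000 nM to 60000 nM, meaning an expected step of an at least 2.5-fold lower number from compound 1 to compound 4 (0.39 log units; beyond the scatter).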

Compound 4, half-maximal inhibitory concentration: 14100 nM
Compound 4: middle estimate off by 1.4-fold (0.15 log units), on the high side, and the stated range covers the measured number.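

In this assay, methyl in place of hydrogen on the saturated chain carbon bound to the amide-type nitrogen and an aromatic carbon produces no change beyond the scatter, printed as a 1.4-fold lower number from compound 3 to compound 4 (0.14 log units; within the scatter). With 1-phenylethyl on the amide-type nitrogen, a second phenyl-bearing amide gives a readable number, printed as an at least 3.5-fold lower number from compound 1 to compound 4 (0.54 log units; beyond the scatter) and as an at least 3.5-fold lower number from compound 2 to compound 4 (0.54 log units; beyond the scatter), so among the four compounds, both with a phenyl read and the hydrogen and butyl amides do not. These two steps are bounds and not sizes, as each starts from a compound at a limit: the limit of > 50000 nM in this assay, at which 2 of the 4 values shown sit.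

The compounds shown leave open whether the opposite configuration at the defined stereocentre reads differently from compound 4. They also leave open how a 2-phenylethyl group on the amide-type nitrogen, or an amine or a carboxylic acid on the phenyl ring, would read.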